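Benzyl to 4-methylphenyl: working notes on compound 4

The compounds below may be only part of what the source reports. "The series", "measured", "known", "first", "only" and "open" are said of these compounds alone.

In a functional assay on IMR-32 cells (Homo sapiens) for antiproliferative activity, with a stated time of 72 h (a lower number here means a stronger inhibitor, a higher number a weaker inhibitor), compound 3 (`CN(C)c1ccc(C(=O)N(CCC(=O)NCc2ccccc2)Cc2ccc(C(=O)NO)cc2)cc1`) gives 840 nM. Compound 2 (`Cc1ccc(NC(=O)CCN(Cc2ccc(C(=O)NO)cc2)C(=O)c2ccccc2)cc1`) gives 550 nM, which lies within the scatter of the value for compound 3. Compound 1 (`Cc1ccc(NC(=O)CCN(Cc2ccc(C(=O)NO)cc2)C(=O)c2cc(C)cc(C)c2)cc1`) gives 210 nM, a lower number than that of compound 3 by more than the scatter.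

Compound 4 (`Cc1ccc(NC(=O)CCN(Cc2ccc(C(=O)NO)cc2)C(=O)c2ccc(N(C)C)cc2)cc1`) differs from compound 3 in one place: 4-methylphenyl in place of benzyl on an amide-type nitrogen. The change puts 4-methylphenyl in place of benzyl on an amide-type nitrogen, and compound 1 and compound 2 already carry 4-methylphenyl there.

For the measured compounds named here, no measured step covers this change directly. Going by the values given here, the only step available, a 2.6-fold higher number from compound 1 to compound 2 (0.42 log units; beyond the scatter), is modest and lies elsewhere in the molecule, so it gives only a rough sense of how far a single change has moved the numbers in this small set. Compound 2 and compound 3 differ in more than one place, so their two values do not isolate the effect of the swap.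

No step beyond the scatter is expected in this assay, and the direction, towards a slightly lower number, is tentative. The expected change is a 1.7-fold lower number from compound 3 to compound 4 (0.23 log units; within the scatter). For compound 4 the estimated value is 500 nM, with an expected range of 180 nM to 1300 nM.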

Compound 4, half-maximal inhibitory concentration: 300 nM
The estimate for compound 4 lay 1.7-fold (0.22 log units) above the measured number, and the stated range covers the measured number.
By their numbers in this assay, from the lowest: compounds 1, 4, 2 and 3 (each within the scatter of the next, the first and the last beyond it).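

For the compounds shown here, the benzyl-to-4-methylphenyl swap on the amide-type nitrogen now has a direct reading in this assay (a 2.8-fold lower number from compound 3 to compound 4 (0.45 log units; beyond the scatter)), with the 4-(dimethylamino)phenyl on the carbonyl carbon held constant, whereas the earlier compounds differed from compound 3 in more than one place. With 4-methylphenyl kept on that nitrogen, dimethylamino in place of hydrogen on an aromatic carbon gives a step inside the scatter (a 1.8-fold lower number from compound 2 to compound 4 (0.26 log units; within the scatter)), and so does 4-(dimethylamino)phenyl in place of 3,5-dimethylphenyl on the carbonyl carbon (a 1.4-fold higher number from compound 1 to compound 4 (0.15 log units; within the scatter)), so neither of these two changes resolves compound 4 from its neighbour. No measurement shown here accounts for the step at the nitrogen.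

The swap changes two things at once, the ring's attachment to the nitrogen and the added methyl, and a plain phenyl or a 4-methylbenzyl group at that place would be needed to read them apart. As far as these compounds go, whether the step extends to other groups there, such as 4-chlorophenyl or 2-phenylethyl, also remains open.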